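Two Chlorines in Place of a Nitro Group

The source may hold more compounds than are shown below. What is called first, only, known or untested is meant among the compounds shown, and "the series" means these compounds.

Among the compounds with values here, compound 3 `N=C1S/C(=C\c2ccc(OCc3ccccc3)cc2)C(=O)N1c1ccc([N+](=O)[O-])cc1` stands second highest of the three numbers so far in an ADME assay on RAW264.7 cells (Mus musculus) for cytotoxicity, read by MTT assay, with a stated time of 48 h, tested at 50 uM (a higher number here means more inhibition at the concentration tested (going by the name of the read-out), a lower number less inhibition), where compound 3 gives 17.3%. Its nearest neighbour is compound 1 `N=C1S/C(=C\c2ccc(OCc3ccccc3)cc2)C(=O)N1c1ccc(Cl)cc1`, which gives 16.4%, and the furthest is compound 2 `N=C1S/C(=C\c2ccc(OCc3ccccc3)cc2)C(=O)N1c1ccccc1[N+](=O)[O-]`, which gives 24.4%. Every measured step lies within the scatter: a number 8 percentage points higher from compound 1 to compound 2 (within the scatter), a number 0.9 percentage points higher from compound 1 to compound 3 (within the scatter) and a number 7.1 percentage points lower from compound 2 to compound 3 (within the scatter). Compound 4 `N=C1S/C(=C\c2ccc(OCc3ccccc3)cc2)C(=O)N1c1ccc(Cl)cc1Cl` differs from compound 3 in one place: 2,4-dichlorophenyl in place of 4-nitrophenyl on an amide-type nitrogen in a ring. The step of a number 7.1 percentage points lower from compound 2 to compound 3 (within the scatter) altered the group on the same nitrogen, and the step of a number 0.9 percentage points higher from compound 1 to compound 3 (within the scatter) swapped chloro for nitro, neither beyond the scatter. Compound 4 is therefore expected to show no step beyond the scatter, a number 1.7 percentage points higher from compound 3 to compound 4 (within the scatter). The estimate for compound 4 is 19%, within 8% to 31%.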

Compound 4, a percentage reported as inhibition, at one concentration (the size of the read-out at that concentration, not a potency): 13.8%
Estimate against measurement, compound 4: 5.2 percentage points above; the measured number falls inside the stated range.
By their numbers in this assay, from the lowest: compounds 4, 1, 3 and 2 (each within the scatter of the next, the first and the last beyond it).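

Within the data shown here, on the amide-type nitrogen, the first change beyond the scatter in this assay appears with 2,4-dichlorophenyl in place of 2-nitrophenyl, a number 10.6 percentage points lower from compound 2 to compound 4 (beyond the scatter) and still modest. Replacing 4-nitrophenyl with the same group gives a number 3.5 percentage points lower from compound 3 to compound 4 (within the scatter) and adding chloro in place of hydrogen gives a number 2.6 percentage points lower from compound 1 to compound 4 (within the scatter) so the size of the step depends on which compound it starts from. Nothing measured here accounts for these differences.

Going by these compounds, whether an amine or a carboxylic acid on this phenyl ring would stay within the same narrow range remains open.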